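The source may report more compounds than this note shows. Statements on the series, on what has been measured and on what is new or still open speak of the compounds shown alone.

Measured compounds: compound 1 `CC(=O)c1c(NNc2ccc(Cl)cc2)cc(C)oc1=O`, 58.6%; compound 2 `CC(=O)c1c(NNc2ccc(Br)cc2)cc(C)oc1=O`, 40.4%; compound 3 `Cc1ccc(-n2nc3cc(C)oc(=O)c3c2C)cc1`, 54%.

In a functional assay on the whole organism for inhibition, with Rattus norvegicus as the target, read by paw edema, with a stated time of 3 h, at a dose of 50 mg/kg (a lower number here means less inhibition, a higher number more inhibition at the dose given (going by the name of the read-out)), compound 3 gives 54%, which lies within the scatter of the value of compound 1, while compound 2 is lower by an amount beyond the scatter. Among the compounds with values here, the only step among the measured compounds, a number 18.2 percentage points lower from compound 1 to compound 2 (beyond the scatter), concerns a change on the core of compound 1 and does not touch the change from compound 3 to compound 4 `COc1ccc(-n2nc3cc(C)oc(=O)c3c2C)cc1`: methoxy in place of methyl on an aromatic carbon. Within the data shown here, no measured step bears on this change, so no shift beyond the scatter is expected in this assay, and the step of a number 2 percentage points lower from compound 3 to compound 4 (within the scatter) is an estimate of no change. Compound 4 is therefore expected to give about 52%, between 35% and 68%.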

Compound 4, a percentage reported as inhibition, in the whole organism at one dose (the size of the read-out at that dose, not a potency): 57.6%
The estimate for compound 4 lay 5.6 percentage points below the measured number, within the range that was stated.
By their numbers in this assay, from the lowest: compound 2; then compounds 3, 4 and 1 (each within the scatter of the next).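

On the aromatic carbon para to a large group, methoxy in place of methyl gives a number 3.6 percentage points higher from compound 3 to compound 4 (within the scatter) in this assay, so at this position the added oxygen, a hydrogen-bond acceptor, brings no shift beyond the scatter. Within the data shown here, this is the first step read on the core of compound 3, since the only earlier step lay on the core of compound 1. Nothing measured here offers a reason for this result.

Going by these compounds, what an amine or a carboxylic acid would give at this place stays open. So does whether chloro and bromo would differ on this core as they do on the core of compound 1.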